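From Cyclohexyl to Phenyl on an Amine Nitrogen

A few compounds are considered here, and "the series" means these few. Any claim that something is new, unique, unknown or untested is made for them only; others in the source may bear on it.

Measured so far in a functional assay on MCF7 cells (Homo sapiens) for antiproliferative activity; a higher number here means a weaker inhibitor, a lower number a stronger inhibitor:
Compound 1 `CC(C)=CCc1cc(C(=O)Nc2cc3ccc(OCCCNCC(C)C)c(C)c3oc2=O)ccc1O`: 1320 nM
Compound 2 `CC(C)=CCc1cc(C(=O)Nc2cc3ccc(OCCCNC4CCCCC4)c(C)c3oc2=O)ccc1O`: 1070 nM

With only these two values available, compound 2 stands within the scatter of compound 1, and the data do not separate them. The next compound, compound 3 `CC(C)=CCc1cc(C(=O)Nc2cc3ccc(OCCCNc4ccccc4)c(C)c3oc2=O)ccc1O`, keeps the shared core of compound 2 but carries phenyl in place of cyclohexyl on an amine nitrogen. Its other neighbour there is a saturated chain carbon.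

Among the measured compounds shown here, only one measured step bears on this change: a 1.2-fold lower number from compound 1 to compound 2 (0.09 log units; within the scatter). That step exchanged isobutyl for cyclohexyl on the same nitrogen and stayed within the scatter. For the measured compounds named here, it is thin evidence, since neither measured compound has phenyl at this place, and no measured step shows what phenyl does there. The expectation is therefore for no step beyond the scatter, held with wide uncertainty. The estimated change is a 1.2-fold higher number from compound 2 to compound 3 (0.08 log units; within the scatter). For compound 3 the expected value is 1300 nM, with an estimated range of 500 nM to 3500 nM.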

Compound 3, half-maximal inhibitory concentration: > 50000 nM
Compound 3: no number, only a limit (the forecaster's own chance of this, stated with the estimate: 5%); middle value at least 38-fold (1.58 log units) from the limit.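

In this assay, compound 3 has a limit and not a number: the limit of > 50000 nM in this assay, at which 1 of the 3 values shown sits.

Placing phenyl on the amine nitrogen gives an at least 46-fold higher number from compound 2 to compound 3 (1.66 log units; beyond the scatter) and, measured against the isobutyl compound, an at least 37-fold higher number from compound 1 to compound 3 (1.57 log units; beyond the scatter). The earlier pair showed only that isobutyl and cyclohexyl on this nitrogen could not be told apart, whereas these steps show that the group at this place can decide whether activity in this assay is retained at all: cyclohexyl and phenyl have the same count of heavy atoms and differ in that one ring is non-aromatic and the other aromatic, yet the steps lie far beyond the scatter.

The compounds shown do not say whether this loss belongs to the aromatic ring itself or to the anilino unit as a whole, a question that a benzyl group on the same nitrogen would address. On these data alone, the full size of both steps also stays open, as compound 3 has only a limit.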